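A Change of Ring Substituent and Expected Cell Toxicity

The compounds below may be only part of what the source reports. "The series", "measured", "known", "first", "only" and "open" are said of these compounds alone.

Compound 1 `O=C(N/N=C/c1ccccc1)c1cnccn1` gives 100% in an ADME assay on J774 cells (Mus musculus) for cytotoxicity, read by MTT assay, with a stated time of 48 h, tested at 50 ug/mL (on this read-out lower numbers stand for a stronger effect and higher numbers for a weaker effect at the one concentration tested), the highest of the two numbers available. Compound 2 `O=C(N/N=C/c1ccc(Cl)cc1)c1cnccn1` gives 83% in this assay, and the step of a number 17 percentage points lower from compound 1 to compound 2 (beyond the scatter) follows from chloro in place of hydrogen on an aromatic carbon. Compound 3 `CCOc1cccc(/C=N/NC(=O)c2cnccn2)c1` has not yet been measured in this assay; it differs from compound 1 by ethoxy in place of hydrogen on an aromatic carbon. Within the data shown here, the only measured step that bears on this change is the one from compound 1 to compound 2, which was modest and lay beyond the scatter; the entering group there was chloro rather than ethoxy, so it is only a loose guide. A step of a number 10 percentage points lower from compound 1 to compound 3 (within the scatter) in this assay is therefore expected, at most a modest lowering and possibly none beyond the scatter. The estimate for compound 3 in this assay is 90%, within a range from 72% to 105%.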

Compound 3, a percentage reported as activity, at one concentration (the size of the read-out at that concentration, not a potency): 74%
Beside the measured number, compound 3's estimate is 16 percentage points above it; the measured number falls inside the stated range.
By their numbers in this assay, from the lowest: compounds 3 and 2 (each within the scatter of the next); then compound 1.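

In this assay, ethoxy in place of hydrogen on an aromatic carbon, here meta to a large group, brings a number 26 percentage points lower from compound 1 to compound 3 (beyond the scatter). Until now, only chloro had shown a lowering beyond the scatter on this six-membered aromatic ring of carbon only, so the lowering is no longer tied to that one group. An entering group of carbon and oxygen, with no ring and no net charge, also produces it. No measurement available here accounts for this lowering.

The compounds shown leave open whether an amine, a carboxylic acid or a longer chain such as butoxy, placed on the same aromatic carbon, would lower the number as ethoxy does. They also leave open whether ethoxy at another place on the ring would give a step of similar size.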